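The source may hold more compounds than are shown below. What is called first, only, known or untested is meant among the compounds shown, and "the series" means these compounds.

In a functional assay on aorta with Voltage-dependent L-type calcium channel subunit alpha-1C (Oryctolagus cuniculus) as the target (on this read-out lower numbers stand for a shorter-lived compound and higher numbers for a longer-lived compound), compound 3 `CCO/C(O)=C1\C(C)=NC(C)=C(C(=O)OCCCN2C(=O)c3ccccc3S2(=O)=O)C1c1ccccc1C(F)(F)F` gives 0.155 h. Compound 1 `CCO/C(O)=C1\C(C)=NC(C)=C(C(=O)OCCCN2C(=O)c3ccccc3S2(=O)=O)C1c1cccc(Cl)c1Cl` gives 0.2 h and compound 2 `CC1=NC(C)=C(C(=O)OCCCN2C(=O)c3ccccc3S2(=O)=O)C(c2cccc(Cl)c2Cl)/C1=C(\O)OC(C)C` gives 0.185 h; these three numbers all lie within the usual scatter of one another, so none of them stands apart. Compound 4 `CC1=NC(C)=C(C(=O)OCCCN2C(=O)c3ccccc3S2(=O)=O)C(c2ccccc2C(F)(F)F)/C1=C(\O)OCC1CCCCO1` differs from compound 3 by oxan-2-yl in place of methyl on a saturated chain carbon bound to an oxygen on an unsaturated carbon. Going by the values given here, the one measured step at this same place, a 1.1-fold lower number from compound 1 to compound 2 (0.03 log units; within the scatter), put a methyl there and changed little; the other step, a 1.3-fold lower number from compound 1 to compound 3 (0.11 log units; within the scatter), exchanged 2,3-dichlorophenyl for 2-(trifluoromethyl)phenyl and also stayed within the scatter. Among the compounds with values here, no measured step shows this place to move the number, so the expected step of a 1.0-fold higher number from compound 3 to compound 4 (0.01 log units; within the scatter) is none beyond the scatter. Compound 4 is estimated at 0.16 h, between 0.08 h and 0.35 h.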

Compound 4, half-life: 0.0767 h
Beside the measured number, compound 4's estimate is 2.1-fold (0.32 log units) above it; the whole stated range lies above it.
By their numbers in this assay, from the lowest: compound 4; then compounds 3, 2 and 1 (each within the scatter of the next).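

Oxan-2-yl in place of methyl at this place gives a 2.0-fold lower number from compound 3 to compound 4 (0.31 log units; beyond the scatter) and is the only step shown that goes beyond the scatter. So this place, which barely responded to the small methyl step among the earlier compounds, can move the half-life when a larger group carrying a ring enters. Nothing measured here explains the fall.

The compounds shown leave open whether the ring itself or its oxygen goes with the shorter half-life. Cyclohexyl or a longer open chain at this place would help separate the two.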